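The source may report more compounds than this note shows. Statements on the series, on what has been measured and on what is new or still open speak of the compounds shown alone.

Measured so far:
compound 1 `CC1=C(C(=O)C2CC2)C(c2cccs2)NC(=O)N1`: 1%
compound 2 `CCCC(=O)C1=C(C)NC(=O)NC1c1cccs1`: 2%
compound 3 `CC1=C(C(=O)SC(C)C)C(c2ccco2)NC(=O)N1`: 5%

All three numbers come from an assay on membranes from CHO cells for displacement of a labelled ligand from adenosine receptor A1 (Homo sapiens), read by scintillation counting, with a stated time of 60 min, tested at 1 uM; on this read-out lower numbers stand for less inhibition and higher numbers for more inhibition at the one concentration tested (going by the name of the read-out). In this assay compound 3 gives 5%, and that number lies within the usual scatter of the numbers of compound 2 and compound 1, so none of the three is told apart from the others; all of them show little inhibition at the single concentration tested.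

The compound to be measured next is compound 4 `CC1=C(C(=O)SC(C)C)C(c2cccs2)NC(=O)N1`. It differs from compound 3 in one place: thiophen-2-yl in place of furan-2-yl on a saturated ring carbon. Compound 1 and compound 2 already carry thiophen-2-yl on that same ring carbon and give low numbers, while compound 3 carries furan-2-yl and also gives a low number.

Among the measured compounds shown here, the only measured step, a number 1 percentage points higher from compound 1 to compound 2 (within the scatter), concerns the group on the carbonyl carbon, not the aromatic ring, and stayed within the scatter. For the measured compounds named here, no measured step swaps furan-2-yl for thiophen-2-yl, so no direct guide exists. The step of a number 2 percentage points lower from compound 3 to compound 4 (within the scatter) is expected to stay within the scatter. Compound 4 is therefore estimated at 3%, with a range from -5% to 12%.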

Compound 4, a percentage reported as inhibition, at one concentration (the size of the read-out at that concentration, not a potency): 1%
Compound 4: middle estimate off by 2 percentage points, on the high side; measured number inside the range.
By their numbers in this assay, from the lowest: compounds 1, 4, 2 and 3 (each within the scatter of the next).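

Swapping furan-2-yl for thiophen-2-yl on the saturated ring carbon gives, in this assay, a number 4 percentage points lower from compound 3 to compound 4 (within the scatter) and so offers the first direct comparison of these two rings at this position, which the read-out does not tell apart when the isopropylsulfanyl carbonyl group stays in place. With thiophen-2-yl held constant, the group on the carbonyl carbon also makes no visible difference: isopropylsulfanyl in place of propyl gives a number 1 percentage points lower from compound 2 to compound 4 (within the scatter) while isopropylsulfanyl in place of cyclopropyl gives no change at the digits printed from compound 1 to compound 4 (within the scatter) and all of these steps therefore stay within the noise of the measurement. No separate measurement is available to explain these numbers.

As far as these compounds go, all four compounds show little inhibition at the single concentration tested, so it remains open whether either position can move the read-out beyond the scatter at all. A phenyl ring on the saturated ring carbon, or a longer chain or an amine on the carbonyl carbon, might behave differently, and the compounds shown give no basis for predicting the outcome of those changes.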